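Replacing the dimethylamino end of the amide chain in compound 1

A few compounds are considered here, and "the series" means these few. Any claim that something is new, unique, unknown or untested is made for them only; others in the source may bear on it.

Compound 1 `Cc1c(C(=O)NCCCN(C)C)oc2ccc(N(Cc3ccc(Br)cc3)S(=O)(=O)c3ccc(Br)cc3)cc12`: 3070 nM
Compound 2 `Cc1c(C(=O)NCCS(C)(=O)=O)oc2ccc(N(Cc3ccc(Br)cc3)S(=O)(=O)c3ccc(Br)cc3)cc12`: > 40000 nM
Compound 3 `Cc1ccc(NC(=O)c2oc3ccc(N(Cc4ccc(Br)cc4)S(=O)(=O)c4ccc(Br)cc4)cc3c2C)nc1`: > 40000 nM

Within the data shown here, in a functional assay on HCT-116 cells (Homo sapiens) for antiproliferative activity, read by MTT assay, with a stated time of 48 h (on this read-out lower numbers stand for stronger inhibition and higher numbers for weaker inhibition), compound 1 gives 3070 nM, the only numerical value among the three measured compounds. For compound 2 the assay reports only a limit, > 40000 nM. For compound 3 likewise only a limit is reported, > 40000 nM. Both limits sit at the same point, (the limit of > 40000 nM in this assay, at which 2 of the 3 values shown sit).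

Compound 4 `Cc1c(C(=O)NCCNc2ccccc2)oc2ccc(N(Cc3ccc(Br)cc3)S(=O)(=O)c3ccc(Br)cc3)cc12` has not yet been measured. It differs from compound 1 in one place: anilino in place of (dimethylamino)methyl on a saturated chain carbon, two bonds along the chain from an amide-type nitrogen.

Among the measured compounds shown here, two measured steps bear on this change. The step of an at least 13-fold higher number from compound 1 to compound 2 (1.11 log units; beyond the scatter) alters the same chain carbon, two bonds along the chain from the amide-type nitrogen, and the step of an at least 13-fold higher number from compound 1 to compound 3 (1.11 log units; beyond the scatter) replaces the whole 3-(dimethylamino)propyl chain. Both are large and run in the direction of weaker inhibition. The step from compound 2 to compound 3, a step that the two limits leave unreadable from compound 2 to compound 3, cannot be read because both values are limits.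

On this basis compound 4 is expected to show a large step toward weaker inhibition, a 6.5-fold higher number from compound 1 to compound 4 (0.81 log units; beyond the scatter), with a real chance that only a limit is reported. Compound 4 is estimated at 20000 nM, within a range from 6000 nM to 60000 nM.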

Compound 4, half-maximal inhibitory concentration: > 40000 nM
Compound 4 gave a limit, no number; the forecaster's own chance of this, stated with the estimate: 45%; at least 2.0-fold (0.30 log units) between middle value and limit.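

The step to the anilino group, an at least 13-fold higher number from compound 1 to compound 4 (1.11 log units; beyond the scatter), is the second replacement on this saturated chain carbon that ends in a limit and not in a number, after the methylsulfonyl group of compound 2. This time the entering group holds a nitrogen, as the leaving group does, so among the compounds shown a nitrogen in the chain does not by itself keep a measurable value in this assay; of the four, only compound 1, with its 3-(dimethylamino)propyl chain, gives a number. Compound 2, compound 3 and compound 4 cannot be ordered against one another, and the steps among them cannot be read: the limit of > 40000 nM in this assay, at which 3 of the 4 values shown sit.

The compounds shown leave open whether the number of compound 1 depends on the dimethylamino group itself or would persist with another amine at the chain end, such as a pyrrolidine or a morpholine. They also leave open how a shorter 2-(dimethylamino)ethyl chain or a longer 4-(dimethylamino)butyl chain would read in this assay.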